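Amide substituent changes in a lipopeptide series

The source may report more compounds than this note shows. Statements on the series, on what has been measured and on what is new or still open speak of the compounds shown alone.

Measured in an assay on HEK293 cells for agonist activity at Toll-like receptor 2 (Homo sapiens); on this read-out higher numbers stand for an effect only at larger amounts of compound and lower numbers for an effect already at smaller amounts:
compound 1 `CCCCCCCCCCCC(=O)OC[C@H](CSC[C@@H](N)C(=O)NCCO)OC(=O)CCCCCCCCCCC`: 24 nM
compound 2 `CCCCCCCCCCCC(=O)OC[C@H](CSC[C@@H](N)C(=O)N[C@H](C)CO)OC(=O)CCCCCCCCCCC`: 22200 nM
compound 3 `CCCCCCCCCCCC(=O)OC[C@H](CSC[C@@H](N)C(=O)NC1(CO)CC1)OC(=O)CCCCCCCCCCC`: 265 nM

Compound 1 stands at the lowest number of the three. Its nearest neighbour is compound 3, with an 11-fold higher number from compound 1 to compound 3 (1.04 log units; beyond the scatter); the furthest is compound 2, with a 930-fold higher number from compound 1 to compound 2 (2.97 log units; beyond the scatter). Between those two the step is an 84-fold lower number from compound 2 to compound 3 (1.92 log units; beyond the scatter), so the size of the effect depends strongly on which group replaces the 2-hydroxyethyl.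

Compound 4 `CCCCCCCCCCCC(=O)OC[C@H](CSC[C@@H](N)C(=O)NC(C)c1ccc(O)cc1)OC(=O)CCCCCCCCCCC` differs from compound 1 in one place: 1-(4-hydroxyphenyl)ethyl in place of 2-hydroxyethyl on an amide-type nitrogen. Both measured steps bear on this change, since each alters the same group on the amide-type nitrogen of compound 1. In compound 2 the methyl on the saturated chain carbon bound to the nitrogen gave the largest step seen; compound 4 likewise carries a methyl-bearing carbon on that nitrogen, together with the 4-hydroxyphenyl ring. Going by the values given here, a large step towards higher numbers in this assay is therefore expected, probably closer to the step to compound 2 than to the step to compound 3, though no measured pair carries an aromatic ring here and the uncertainty is wide.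

Compound 4 is estimated at 6000 nM, with a range from 600 nM to 60000 nM. This expectation corresponds to a 250-fold higher number from compound 1 to compound 4 (2.40 log units; beyond the scatter).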

Compound 4, half-maximal effective concentration: 2890 nM
The estimate for compound 4 lay 2.1-fold (0.32 log units) above the measured number, within the range that was stated.
By their numbers in this assay, from the lowest: compound 1; then compound 3; then compound 4; then compound 2.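

Working notes: in this assay, a much larger group carrying an aromatic ring is tolerated at this amide-type nitrogen only in part, with a 120-fold higher number from compound 1 to compound 4 (2.08 log units; beyond the scatter). So far, all three replacements of 2-hydroxyethyl on this nitrogen raise the number, and none comes near compound 1, though the size of the rise varies widely with the group. A methyl-bearing carbon on the nitrogen does not by itself fix the number at the level of compound 2, since the 4-hydroxyphenyl group in place of the hydroxymethyl arm gives a 7.7-fold lower number from compound 2 to compound 4 (0.89 log units; beyond the scatter), while the same compound still sits on the far side of the cyclopropyl compound, with an 11-fold higher number from compound 3 to compound 4 (1.04 log units; beyond the scatter).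

Nothing available accounts for why these groups order as they do. Still open, as far as these compounds go, is how a 2-aminoethyl, a 3-hydroxypropyl or a plain 1-phenylethyl group on this nitrogen would read, and with that whether the hydroxyl on the ring of compound 4 contributes to its number at all.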